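Swapping fluoro for difluoromethoxy: cytotoxicity outlook

The compounds below may be only part of what the source reports. "The series", "measured", "known", "first", "only" and "open" are said of these compounds alone.

Compound 2 `O=[N+]([O-])c1cn2c(n1)OC[C@@H](OCc1ccc(-c3ccc(F)cc3)s1)C2` is the point of departure. In an ADME assay on Vero cells (Chlorocebus sabaeus) for cytotoxicity, with a stated time of 72 h (a higher number here means a weaker inhibitor, a lower number a stronger inhibitor), compound 2 gives only a limit, > 128000 nM, not a number. Its measured neighbour, compound 1 `N#Cc1ccc(-c2ccc(CO[C@@H]3COc4nc([N+](=O)[O-])cn4C3)s2)cc1`, carries a cyano group where compound 2 carries fluoro. In this assay compound 1 likewise gives only a limit, > 128000 nM. The step that the two limits leave unreadable from compound 1 to compound 2 therefore cannot be read as a number; both compounds sit at the same limit (the limit of > 128000 nM in this assay, at which 2 of the 2 values shown sit). Compound 3 `O=[N+]([O-])c1cn2c(n1)OC[C@@H](OCc1ccc(-c3ccc(OC(F)F)cc3)s1)C2` is the untested member. Going from compound 2 to compound 3, (difluoromethoxy in place of fluoro on an aromatic carbon). For the measured compounds named here, the one measured step, from compound 1 to compound 2, gives no direction for this change because both of its ends sit at the limit (the limit of > 128000 nM in this assay, at which 2 of the 2 values shown sit). With both tested compounds at the limit, compound 3 is expected to stay there as well, so the step of a number no higher from compound 2 to compound 3 (the limit leaves the size open) is expected to be none beyond the scatter. For compound 3 the estimate in this assay is 128000 nM, with a range from 64000 nM to 256000 nM, most likely reported once more as a limit rather than a number.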

Compound 3, half-maximal inhibitory concentration: > 128000 nM
Compound 3: no number, only a limit; the forecaster's own chance of this, stated with the estimate: 85%; the middle value sits exactly at the limit.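

In this assay compound 3 gives > 128000 nM, which is a limit and not a number. No step among compound 1, compound 2 and compound 3 can be read, because all three sit at the same limit: the limit of > 128000 nM in this assay, at which 3 of the 3 values shown sit.

The compounds shown leave open whether cyano, fluoro and difluoromethoxy differ at all in cytotoxicity.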